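Two Aryl Variants and a Third on One Shared Core

The source may hold more compounds than are shown below. What is called first, only, known or untested is meant among the compounds shown, and "the series" means these compounds.

Compound 1 `CCCS(=O)(=O)Nc1ccc(F)c(C(=O)c2n[nH]c3ncc(-c4ccccc4F)cc23)c1F` and compound 2 `CCCS(=O)(=O)Nc1ccc(F)c(C(=O)c2n[nH]c3ncc(-c4ccc(F)cc4)cc23)c1F` share one core and differ only in the aromatic ring attached to it. In an assay for binding affinity to dual specificity mitogen-activated protein kinase kinase 4 (Homo sapiens), read by KINOMEscan, tested at 100 nM (a higher number here means a weaker effect of the compound at the concentration tested, a lower number a stronger effect), compound 1 gives 2%, and in this assay compound 2 gives 2.1%. The single measured step, a number 0.1 percentage points higher from compound 1 to compound 2 (within the scatter), shows that moving the fluorine around that ring left the read-out essentially unchanged; on the two numbers shown, compound 1 stands within the scatter of its only neighbour, so no ordering between them can be drawn.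

Compound 3 `CCCS(=O)(=O)Nc1ccc(F)c(C(=O)c2n[nH]c3ncc(-c4cccc(N)c4)cc23)c1F` has not yet been measured in this assay. It differs from compound 1 in one place: 3-aminophenyl in place of 2-fluorophenyl on an aromatic carbon. Among the compounds with values here, the only step that bears on this change is the one from compound 1 to compound 2, and it was within the scatter; no measured pair exchanges a fluorine for an amino group on that ring, so the data give no guide beyond this.

On that basis the expected step is a number 2 percentage points higher from compound 1 to compound 3 (within the scatter), that is, no change beyond the scatter. The estimate for compound 3 in this assay is 4%, with a range from 1% to 15%.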

Compound 3, a percentage reported as activity, at one concentration (the size of the read-out at that concentration, not a potency): 1.6%
Estimate against measurement, compound 3: 2.4 percentage points above; measured number inside the range.
By their numbers in this assay, from the lowest: compounds 3, 1 and 2 (each within the scatter of the next).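

Measured in this assay, the exchange for 3-aminophenyl shows a number 0.4 percentage points lower from compound 1 to compound 3 (within the scatter) and a number 0.5 percentage points lower from compound 2 to compound 3 (within the scatter) so neither step lies beyond the scatter. Within the data shown here, the earlier pair showed only that a fluorine could change its place on this ring without a change beyond the scatter; the new result extends this to a different substituent, since the fluorine leaves altogether and an amino group enters, bringing the hydrogen-bond donor and acceptor counted for 3-aminophenyl, and the read-out of compound 3 still cannot be told apart from those of compound 1 and compound 2. No accompanying measurement is available that could account for this insensitivity at the position.

From the compounds shown here alone, whether a carboxylic acid or a longer chain, such as an aminomethyl or aminoethyl group, on this ring would move the read-out beyond the scatter remains open. Going by these compounds, the read-out also comes from one concentration and gives only the size of the effect there, so whether compound 1, compound 2 and compound 3 would show a stronger or weaker effect relative to one another at any other concentration remains open as well.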